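Moving the Ring Attachment Point Once More

This account rests on a few compounds, and the source may have more. Where it says the series, first, only, none or still open, it means among the compounds named here.

Three compounds sharing one core were tested in an assay on isolated protein for inhibition of Fatty-acid amide hydrolase 1 (Homo sapiens), with a stated time of 60 min; on this read-out lower numbers stand for stronger inhibition and higher numbers for weaker inhibition. Compound 1 `O=C(Nc1noc2ccccc12)N1CCN(Cc2cccc(Oc3ccc(Cl)cc3)c2)CC1` gives 10 nM. Compound 2 `O=C(Nc1cccn2ccnc12)N1CCN(Cc2cccc(Oc3ccc(Cl)cc3)c2)CC1` gives 310 nM. Compound 3 `O=C(Nc1ccc2nccn2c1)N1CCN(Cc2cccc(Oc3ccc(Cl)cc3)c2)CC1` gives 100 nM, which is the second highest of the three numbers; the step of a 10-fold higher number from compound 1 to compound 3 (1.00 log units; beyond the scatter) is modest, and the step of a 3.1-fold lower number from compound 2 to compound 3 (0.49 log units; beyond the scatter) is also modest, both beyond the scatter.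

Compound 4 `O=C(Nc1cccc2nccn12)N1CCN(Cc2cccc(Oc3ccc(Cl)cc3)c2)CC1` is built from the same atoms as compound 3, joined differently: a group of 9 heavy atoms (7 carbon, 2 nitrogen; one five-membered aromatic ring with 2 hetero atoms, one six-membered aromatic ring with 1 hetero atom) in place of a group of 9 heavy atoms (7 carbon, 2 nitrogen; one five-membered aromatic ring with 2 hetero atoms, one six-membered aromatic ring with 1 hetero atom), on an amide-type nitrogen. For the measured compounds named here, only one measured step bears directly on this kind of change, the step of a 3.1-fold lower number from compound 2 to compound 3 (0.49 log units; beyond the scatter), where the same two rings with the same atoms, attached at a different point, shifted the number by a modest amount. The larger steps of a 31-fold higher number from compound 1 to compound 2 (1.49 log units; beyond the scatter) and a 10-fold higher number from compound 1 to compound 3 (1.00 log units; beyond the scatter) involve a different ring type and so speak less directly. A modest change is therefore expected for compound 4 in this assay, the direction uncertain; the step of a 2.0-fold higher number from compound 3 to compound 4 (0.30 log units; within the scatter) is the estimate. Compound 4 is estimated at 200 nM, within 50 nM to 800 nM.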

Compound 4, half-maximal inhibitory concentration: 2.7 nM
Compound 4: the middle estimate sits 74-fold (1.87 log units) above what was measured, outside the stated range (below it).
By their numbers in this assay, from the lowest: compound 4; then compound 1; then compound 3; then compound 2.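

Swapping only how the same atoms are joined, with no atom gained or lost, gives a 37-fold lower number from compound 3 to compound 4 (1.57 log units; beyond the scatter), and the same kind of swap gives a 110-fold lower number from compound 2 to compound 4 (2.06 log units; beyond the scatter). The earlier step of this kind, a 3.1-fold lower number from compound 2 to compound 3 (0.49 log units; beyond the scatter), gave no sign that the attachment point on the amide-type nitrogen could matter this much. The new group also outdoes the best earlier one, with a 3.7-fold lower number from compound 1 to compound 4 (0.57 log units; beyond the scatter), so compound 4 now has the lowest number of the four in this assay, while the counts of atoms, donors and acceptors stay identical across compounds 2, 3 and 4, and nothing available here explains the gap.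

As far as these compounds go, whether the rings of compound 4 keep this number when they carry a methyl group or an amine remains open. So does whether the same order of compounds would hold against any other enzyme.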